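This account rests on a few compounds, and the source may have more. Where it says the series, first, only, none or still open, it means among the compounds named here.

In a functional assay on PC-3 cells (Homo sapiens) for cytotoxicity, read by sulforhodamine B assay (a lower number here means a stronger inhibitor of growth, a higher number a weaker inhibitor of growth), compound 2 `CCOc1ccc(COc2ccccc2OCCNCCOc2c(OC)cccc2OC)cc1` gives 18200 nM, the lower of the two numbers shown, though the gap to compound 1 `COc1ccccc1COc1ccccc1OCCNCCOc1c(OC)cccc1OC`, which gives 30200 nM, is within the scatter: a 1.7-fold lower number from compound 1 to compound 2 (0.22 log units; within the scatter). Compound 3 `COc1cccc(OC)c1OCCNCCOc1ccccc1OCc1ccc(OC(C)C)cc1` differs from compound 2 by methyl in place of hydrogen on a saturated chain carbon bound to an oxygen on an aromatic ring and a saturated chain carbon. Within the data shown here, the only measured step, from compound 1 to compound 2, moved the aryl group on the same chain carbon without leaving the scatter, and no step on the alkoxy chain itself has been run, so little or no movement in this assay beyond the scatter is expected here. Compound 3 is accordingly estimated at 15000 nM, within 6000 nM to 40000 nM. The expected step is a 1.2-fold lower number from compound 2 to compound 3 (0.08 log units; within the scatter).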

Compound 3, concentration for total growth inhibition: 17800 nM
Beside the measured number, compound 3's estimate is 1.2-fold (0.07 log units) below it, within the range that was stated.
By their numbers in this assay, from the lowest: compounds 3, 2 and 1 (each within the scatter of the next).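

In this assay, methyl in place of hydrogen on a saturated chain carbon bound to an oxygen on an aromatic ring and a saturated chain carbon, ethoxy to isopropoxy, gives a 1.0-fold lower number from compound 2 to compound 3 (0.01 log units; within the scatter), the first step shown on the alkoxy chain itself. 4-isopropoxyphenyl in place of 2-methoxyphenyl gives a 1.7-fold lower number from compound 1 to compound 3 (0.23 log units; within the scatter), so neither change leaves the scatter. No evidence on hand explains these results. Still open, from the compounds shown here alone, is whether a longer chain such as n-butoxy, or an amine or a carboxylic acid on this chain, moves the number beyond the scatter.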